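Amide substituent change on the fluorinated core, cytotoxicity series

The source may report more compounds than this note shows. Statements on the series, on what has been measured and on what is new or still open speak of the compounds shown alone.

Measured compounds:
- Compound 1, `CC1=C(C(C)C(=O)N(C)CCN(C)C)c2cc(F)ccc2/C1=C\c1ccc([S+](C)[O-])cc1`: in a functional assay on MDA-MB-231 cells (Homo sapiens) for inhibition, read by CellTiter-Glo, with a stated time of 96 h (on this read-out higher numbers stand for lower toxicity in this test and lower numbers for higher toxicity in this test), compound 1 gives > 50000 nM, which is a limit of the assay.
- Compound 2, `CC1=C(C(C)C(=O)N(CCNC(C)C)C(C)C)c2cc(F)ccc2/C1=C\c1ccc([S+](C)[O-])cc1`: in this assay compound 2 gives 21300 nM.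
- Compound 3, `CC1=C(C(C)C(=O)NCCN2CCNCC2)c2cc(F)ccc2/C1=C\c1ccc([S+](C)[O-])cc1`: in this assay compound 3 gives > 50000 nM, again a limit of the assay.

Among the measured compounds shown here, compound 2 is the only member of the set with a measured number; the other two values sit at the limit of > 50000 nM in this assay, at which 2 of the 3 values shown sit. From compound 1 the step is an at least 2.3-fold lower number from compound 1 to compound 2 (0.37 log units; beyond the scatter), and onward to compound 3 it is an at least 2.3-fold higher number from compound 2 to compound 3 (0.37 log units; beyond the scatter), so compound 2 stands as the most toxic of the three in this test, each of the other two being at least modestly apart from it.

The next compound, compound 4, `CC1=C(C(C)C(=O)N2CCN(CCCN(C)C)CC2)c2cc(F)ccc2/C1=C\c1ccc([S+](C)[O-])cc1`, is not yet measured. Its difference from compound 2 is 4-(3-(dimethylamino)propyl)piperazin-1-yl in place of isopropyl(2-(isopropylamino)ethyl)amino on a carbonyl carbon. Compound 4 thus carries a piperazine ring, as compound 3 does, and no hydrogen-bond donor on the amide nitrogen, as compound 1 does; both of those measured compounds reached (the limit of > 50000 nM in this assay, at which 2 of the 3 values shown sit). The two measured steps that leave compound 2 both go toward higher numbers, so the step to compound 4 is expected to be a 2.3-fold higher number from compound 2 to compound 4 (0.37 log units; beyond the scatter), toward lower toxicity. Compound 4 is expected to give about 50000 nM, with a range of 20000 nM to 150000 nM, most probably reported only as a limit.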

Compound 4, half-maximal cytotoxic concentration: > 50000 nM
Compound 4: only a limit was reported; the forecaster's own chance of this, stated with the estimate: 60%; the middle value sits exactly at the limit.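

In this assay, 4-(3-(dimethylamino)propyl)piperazin-1-yl on the carbonyl carbon, with its six-membered non-aromatic ring and 0 hydrogen-bond donors, replaces the open-chain isopropyl(2-(isopropylamino)ethyl)amino and gives an at least 2.3-fold higher number from compound 2 to compound 4 (0.37 log units; beyond the scatter). Compound 2 therefore remains the only compound with a measured number, while the others, now including a case with the ring bound directly to the carbonyl carbon, stand at a limit of the assay: the limit of > 50000 nM in this assay, at which 3 of the 4 values shown sit. Among the four compounds, a measured number appears only with the isopropyl-bearing substituent of compound 2, and no compound shown goes against this, although the pattern rests on that single compound.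

The steps linking compound 1, compound 3 and compound 4 cannot be read, as each joins two limits, so any order among these three remains unknown. Going by these compounds, it also remains open which part of the substituent in compound 2 goes with its lower number, a question that a diisopropylamino group or a 2-(isopropylamino)ethylamino group on the same carbonyl carbon would address.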